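A few compounds are considered here, and "the series" means these few. Any claim that something is new, unique, unknown or untested is made for them only; others in the source may bear on it.

Measured so far:
- compound 1 `O=[N+]([O-])c1ccccc1Nc1nc(-c2ccncc2)cs1`: 40700 nM
- compound 2 `Cc1cccc(Nc2nc(-c3ccncc3-c3ccc(C(C)C)cc3)cs2)c1`: > 40000 nM; 40700 nM (2 entries)
- compound 3 `COc1ccc(Nc2nc(-c3ccncc3)cs2)cc1`: 14100 nM

In a functional assay on RCC4 cells (Homo sapiens) for inhibition, read by XTT assay, with a stated time of 4 days (on this read-out lower numbers stand for stronger inhibition and higher numbers for weaker inhibition), compound 1 gives 40700 nM, the higher of the two single numbers in the set. The nearest number is that of compound 3, which gives 14100 nM in this assay; the gap between compound 1 and compound 3 lies beyond the usual scatter. Compound 2 is recorded partly as a limit of this assay, (the several entries of compound 2 in this assay, > 40000 nM; 40700 nM (2 entries)), so it contributes no single number to the comparison.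

Within the data shown here, no pair of measured compounds differs in one place, so no measured step exists. Compound 4 `Oc1ccccc1Nc1nc(-c2ccncc2)cs1` differs from compound 1 by hydroxy in place of nitro on an aromatic carbon. Given that compound 1 and compound 3 both sit in the weak range, only a modest step is expected, if any, and none that would clearly exceed the scatter. Compound 4 is expected to give about 25000 nM in this assay, between 8000 nM and 80000 nM, a step of a 1.6-fold lower number from compound 1 to compound 4 (0.21 log units; within the scatter) that is estimated rather than measured.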

Compound 4, half-maximal inhibitory concentration: 12900 nM
Beside the measured number, compound 4's estimate is 1.9-fold (0.29 log units) above it; the range from low to high includes it.
By their numbers in this assay, from the lowest: compounds 4 and 3 (each within the scatter of the next); then compound 1.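

In this assay, hydroxy in place of nitro on an aromatic carbon, ortho to a large group, gives a 3.2-fold lower number from compound 1 to compound 4 (0.50 log units; beyond the scatter) and is modest in size. Among these compounds, this is the first one-place comparison, and it shows that the number in this assay moves with the group at this position, by more than the usual scatter. Among the compounds shown here, the swap brings in a hydrogen-bond donor and leaves fewer heavy atoms, but a single step cannot separate these two differences, and nothing measured so far bears on the cause.

As far as these compounds go, whether an amine, a methoxy group or a carboxylic acid at this position would move the number further remains open. Also open, from the compounds shown here alone, is how the same position behaves with plain hydrogen, which would show whether hydroxy or nitro differs from the unsubstituted ring.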